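A chlorophenyl replaces a dimethoxyphenyl: what to expect

This account rests on a few compounds, and the source may have more. Where it says the series, first, only, none or still open, it means among the compounds named here.

Compound 1, with the structure `COc1cc(OC)c(OC)cc1/C=C/COC(=O)/C=C/c1ccc(OC)c(OC)c1`, was tested in a functional assay on the whole organism (strain Kunming) with Mus musculus as the target, with a stated time of 0.5 h, at a dose of 300 mg/kg by the intraperitoneal route (on this read-out higher numbers stand for a weaker effect at the one dose given and lower numbers for a stronger effect), where compound 1 gives 75%. Two companions share its core and differ only by one added group. Compound 2, `COc1cc(OC)c(OC)cc1/C=C/COC(=O)/C=C/c1cc(OC)c(OC)c(OC)c1`, gives 75%, and compound 3, `COc1cc(OC)c(OC)cc1/C=C/COC(=O)/C=C/c1ccc(OC)c(OC)c1OC`, gives 75%. The step of no change at the digits printed from compound 1 to compound 2 (within the scatter) and the step of no change at the digits printed from compound 1 to compound 3 (within the scatter) both stay within the scatter, so compound 1 stands level with compounds 2 and 3 on the numbers shown; no one of the three can be called stronger or weaker.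

Compound 4, `COc1cc(OC)c(OC)cc1/C=C/COC(=O)/C=C/c1ccccc1Cl`, is not yet measured. It differs from compound 1 by 2-chlorophenyl in place of 3,4-dimethoxyphenyl on a double-bonded chain carbon bound to a double-bonded chain carbon. Both measured steps concern the same part of the molecule as this change, but each only added a methoxy group, whereas here a whole ring substituent is exchanged for one of a different kind. For the measured compounds named here, those two steps were flat, and nothing among the measured compounds points to a direction for a larger exchange. The expected step of no change at the digits printed from compound 1 to compound 4 (within the scatter) is therefore none beyond the scatter, with wider uncertainty than the measured steps carry. Compound 4 is estimated to give 75% in this assay, expected to fall between 50% and 95%.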

Compound 4, a percentage reported as activity, at one dose (the size of the read-out at that dose, not a potency): 50%
Estimate against measurement, compound 4: 25 percentage points above; measured number inside the range.
By their numbers in this assay, from the lowest: compound 4; then compounds 1, 2 and 3 (each within the scatter of the next).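

Exchanging 3,4-dimethoxyphenyl for 2-chlorophenyl on this chain carbon gives a number 25 percentage points lower from compound 1 to compound 4 (beyond the scatter) in this assay, and a lower number here means a stronger effect at the one dose given. The earlier steps only added a methoxy group and left the read-out flat, so this is the first sign among these compounds that the group at this position can shift the result, and the shift is towards a stronger effect, although a single-dose read-out is not a measure of potency. The exchange removes both methoxy groups and brings in a chlorine in a single step, and nothing shown here explains the shift.

The compounds shown therefore leave open whether the gain comes from losing the methoxy groups, from gaining the chlorine, or from both together, a question that a plain phenyl ring at this position would help to separate. Going by these compounds, it also remains open whether other groups on this ring, such as a bromine, a methyl or an amine, would move the read-out in the same direction.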